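Substitution on the Ring Nitrogen of the Five-Membered Ring of a Diol Series

The source may report more compounds than this note shows. Statements on the series, on what has been measured and on what is new or still open speak of the compounds shown alone.

Compound 1 `O[C@H](COCCOC[C@@H](O)Cc1cn(Cc2cccc(-c3ccccc3)c2)nn1)Cc1ccc(-c2ccccc2)cc1`: 10600 nM
Compound 2 `O[C@H](COCCOC[C@@H](O)Cc1c[nH]nn1)Cc1ccc(-c2ccccc2)cc1`: > 100000 nM

In a functional assay on SGC-7901 cells (Homo sapiens) for inhibition, read by MTT assay, with a stated time of 72 h (on this read-out higher numbers stand for weaker inhibition of growth and lower numbers for stronger inhibition of growth), compound 1 gives 10600 nM. Compound 2 gives only a limit of the assay, > 100000 nM, and so stands at the limit of > 100000 nM in this assay, at which 1 of the 2 values shown sits, the weaker end of the two values shown. Compound 3 `N#Cc1ccc(Cn2cc(C[C@H](O)COCCOC[C@@H](O)Cc3ccc(-c4ccccc4)cc3)nn2)cc1` carries 4-cyanobenzyl in place of hydrogen on an aromatic nitrogen. Among the compounds with values here, no measured pair of this kind exists; the comparison rests on compound 1, which gives 10600 nM with a substituted ring nitrogen. A step toward stronger inhibition, beyond the scatter, is expected: an at least 5.0-fold lower number from compound 2 to compound 3 (0.69 log units; beyond the scatter). Compound 3 is estimated at 20000 nM, within 7000 nM to 70000 nM.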

Compound 3, concentration for 50% growth inhibition: 7700 nM
Compound 3: the middle estimate sits 2.6-fold (0.41 log units) above what was measured; the measured number falls inside the stated range.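

In this assay, 4-cyanobenzyl on the aromatic nitrogen now gives a direct single-change comparison with the unsubstituted ring: an at least 12-fold lower number from compound 2 to compound 3 (1.11 log units; beyond the scatter). The size of this step is bounded on one side only, as compound 2 stands at a limit: the limit of > 100000 nM in this assay, at which 1 of the 3 values shown sits. Between the two substituted compounds the step is a 1.4-fold lower number from compound 1 to compound 3 (0.14 log units; within the scatter), so 4-cyanophenyl and 3-phenylphenyl on the saturated chain carbon do not separate here.

On these data alone, whether an aromatic ring on this nitrogen is needed remains open. A plain methyl group, a longer alkyl chain or an aminoethyl chain there would address this.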